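One Trifluoromethyl Removed: Estimating Compound 4

The source may hold more compounds than are shown below. What is called first, only, known or untested is meant among the compounds shown, and "the series" means these compounds.

Compound 1 `O=C(Nc1cc(C(F)(F)F)cc(C(F)(F)F)c1)c1ccc(Sc2ccc(O)cc2)cc1` and compound 2 `O=C(Nc1cccc(C(F)(F)F)c1)c1ccc(Sc2ccc(O)cc2)cc1` share one core, while compound 3 `O=C(Nc1cc(C(F)(F)F)ccc1C(F)(F)F)c1ccc(S(=O)(=O)c2ccc(O)cc2)cc1` is built on another; the difference between the two cores is not broken down here. In a functional assay on CWR22R cells (Homo sapiens) for antiproliferative activity, read by fluorescence and propidium iodide staining, with a stated time of 96 h (on this read-out higher numbers stand for weaker inhibition and lower numbers for stronger inhibition), compound 1 gives 3350 nM, compound 2 gives 5730 nM and compound 3 gives 20700 nM. Compound 3 stands highest of the three numbers, and its steps to compound 2 and to compound 1 both lie beyond the scatter. Among the compounds with values here, the single change between compound 1 and compound 2 is hydrogen in place of trifluoromethyl on an aromatic carbon, and it made a 1.7-fold higher number from compound 1 to compound 2 (0.23 log units; within the scatter).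

Compound 4 `O=C(Nc1ccccc1C(F)(F)F)c1ccc(S(=O)(=O)c2ccc(O)cc2)cc1` has not yet been measured in this assay. It differs from compound 3 by hydrogen in place of trifluoromethyl on an aromatic carbon. Within the data shown here, this is the same kind of change as the one from compound 1 to compound 2, but not the same: in compound 2 the hydrogen sits meta to a trifluoromethyl group, in compound 4 it sits para to a trifluoromethyl group, and the core differs as well. Among the measured compounds shown here, the one measured instance of the change stayed within the scatter, so a small step is expected here too, a 1.4-fold higher number from compound 3 to compound 4 (0.13 log units; within the scatter), resting on a 1.7-fold higher number from compound 1 to compound 2 (0.23 log units; within the scatter). Compound 4 is therefore estimated at 28000 nM, with the estimate spanning 12000 nM to 70000 nM.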

Compound 4, half-maximal inhibitory concentration: 49300 nM
Estimate against measurement, compound 4: 1.8-fold (0.25 log units) below, within the range that was stated.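

In this assay, replacing trifluoromethyl with hydrogen gives a 2.4-fold higher number from compound 3 to compound 4 (0.38 log units; beyond the scatter), a larger step than the earlier one when the two are read by number alone. Set side by side, however, the two steps cannot be told apart, so the change can be carried from the core of compound 1 to the core of compound 3 without a measurable difference in its size: the same change on two cores in this assay, a 1.7-fold higher number (0.23 log units; within the scatter) from compound 1 to compound 2 and a 2.4-fold higher number (0.38 log units; beyond the scatter) from compound 3 to compound 4, 1.4-fold (0.14 log units) apart, within the scatter of two such steps This rests on only two pairs, one step within the scatter and one beyond it, and the change does not sit in the same place in both, so the effect of the core cannot be separated from the effect of position, and nothing can be said of how the change would behave on any other core.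

The compounds shown leave open whether a chlorine, a methyl or a nitrile in place of trifluoromethyl would give a step like that of hydrogen. They also leave open how much the core alone contributes, as no two compounds shown carry the same substituents on the two cores.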